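This account rests on a few compounds, and the source may have more. Where it says the series, first, only, none or still open, it means among the compounds named here.

Measured compounds:
compound 1, `CCCN1CCC(c2noc(COc3ccc(/C=C/C(=O)NO)cc3)n2)CC1`: 69%
compound 2, `O=C(/C=C/c1ccc(OCc2nc(C3CCN(Cc4ccc(F)cc4)CC3)no2)cc1)NO`: 75%

In an assay on isolated protein for inhibition of protein deacetylase HDAC6 (Homo sapiens), read by fluorescence, with a stated time of 1 h, tested at 100 nM (on this read-out higher numbers stand for more inhibition at the one concentration tested (going by the name of the read-out) and lower numbers for less inhibition), compound 1 gives 69%, and compound 2 gives 75% in the same assay. Compound 2 holds the higher of the two numbers, but the step of a number 6 percentage points higher from compound 1 to compound 2 (within the scatter) is within the scatter, so the two compounds cannot be ordered on these data.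

Compound 3, `O=C(/C=C/c1ccc(OCc2nc(C3CCN(Cc4ccc(Br)cc4)CC3)no2)cc1)NO`, is the next compound to be measured. It differs from compound 2 by bromo in place of fluoro on an aromatic carbon. Among the compounds with values here, no measured step touches this aromatic ring: the step of a number 6 percentage points higher from compound 1 to compound 2 (within the scatter) changes the group on the saturated chain carbon bound to the amine nitrogen in the ring, not a substituent on the 4-fluorophenyl, and it is itself within the scatter. With nothing pointing either way, compound 3 is expected to stay close to compound 2, a step of a number 2 percentage points lower from compound 2 to compound 3 (within the scatter), with no change beyond the scatter. Compound 3 is therefore estimated at 73%, between 60% and 86%.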

Compound 3, a percentage reported as inhibition, at one concentration (the size of the read-out at that concentration, not a potency): 58%
The estimate for compound 3 lay 15 percentage points above the measured number, outside the stated range (below it).
By their numbers in this assay, from the lowest: compound 3; then compounds 1 and 2 (each within the scatter of the next).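

The first change made on this aromatic ring is not a silent one: in this assay bromo in place of fluoro gives a number 17 percentage points lower from compound 2 to compound 3 (beyond the scatter) and so moves the number beyond the scatter. The 4-bromophenyl in place of ethyl also gives a change beyond the scatter, a number 11 percentage points lower from compound 1 to compound 3 (beyond the scatter), whereas the 4-fluorophenyl in place of ethyl gave only a number 6 percentage points higher from compound 1 to compound 2 (within the scatter), so across these three compounds the outcome of that replacement depends on the halogen on the ring. Nothing available accounts for this difference between fluoro and bromo.

The compounds shown leave open where a chloro, a methoxy or a plain hydrogen at this same place would fall. With only two halogens compared, at one concentration, no trend along a series of substituents can yet be drawn.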